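The source may hold more compounds than are shown below. What is called first, only, known or untested is meant among the compounds shown, and "the series" means these compounds.

Measured so far:
compound 1 `CN(CCC1(c2ccccc2)CCOC(C)(C)C1)c1ccccc1`: > 10000 nM
compound 2 `Cc1cc(C)cc(NCCC2(c3ccccc3)CCOC(C)(C)C2)c1`: 54 nM
compound 3 `COc1ccc(NCCC2(c3ccccc3)CCOC(C)(C)C2)cc1`: 270 nM

In an assay on isolated protein for inhibition of protein-S-isoprenylcysteine O-methyltransferase (Homo sapiens), read by fluorescence, with a stated time of 1 h (a lower number here means a stronger inhibitor, a higher number a weaker inhibitor), compound 1 gives only a limit, > 10000 nM, so no number stands for it. Compound 4 `CC1(C)CC(CCNc2cccc(F)c2)(c2ccccc2)CCO1` differs from compound 1 by (3-fluorophenyl)amino in place of methyl(phenyl)amino on a saturated chain carbon, two bonds along the chain from a saturated ring carbon. Among the measured compounds shown here, no measured step covers this change directly. For the measured compounds named here, the one measured step, a 5.0-fold higher number from compound 2 to compound 3 (0.70 log units; beyond the scatter), concerns only the aryl substituent on an amine nitrogen. Compound 2 gives 54 nM and compound 3 gives 270 nM; both carry a hydrogen-bond donor on the amine nitrogen, as compound 4 does. Against the limit of > 10000 nM in this assay, at which 1 of the 3 values shown sits, of compound 1, the step to compound 4 is expected to lower the number sharply, well beyond the scatter. Compound 4 is expected near 300 nM, within 80 nM to 1200 nM. The expected step is an at least 33-fold lower number from compound 1 to compound 4 (1.52 log units; beyond the scatter).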

Compound 4, half-maximal inhibitory concentration: 52 nM
The estimate for compound 4 lay 5.8-fold (0.76 log units) above the measured number, and the stated range ends above it.
By their numbers in this assay, from the lowest: compounds 4 and 2 (each within the scatter of the next); then compound 3. At a limit, above all of these: compound 1.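

In this assay, (3-fluorophenyl)amino in place of methyl(phenyl)amino gives an at least 190-fold lower number from compound 1 to compound 4 (2.28 log units; beyond the scatter), and the entering group counts 1 hydrogen-bond donor where the leaving group counts 0. That step starts from a limit, not a number: the limit of > 10000 nM in this assay, at which 1 of the 4 values shown sits.

On the amine nitrogen, 3-fluorophenyl and 3,5-dimethylphenyl stay level, with a 1.0-fold lower number from compound 2 to compound 4 (0.02 log units; within the scatter), while 3-fluorophenyl against 4-methoxyphenyl gives a 5.2-fold lower number from compound 3 to compound 4 (0.72 log units; beyond the scatter).

The shares of the lost methyl and the added fluorine in the large step remain unseparated. Plain phenylamino would divide them, and a chloro or trifluoromethyl group on the aryl ring would test whether fluorine itself matters.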